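From methoxy to hydroxy in a cytotoxicity test

A few compounds are considered here, and "the series" means these few. Any claim that something is new, unique, unknown or untested is made for them only; others in the source may bear on it.

Measured so far in a functional assay on MCF7 cells (Homo sapiens) for cytotoxicity, read by MTT assay, with a stated time of 48 h (a higher number here means a weaker inhibitor, a lower number a stronger inhibitor), are three compounds
- compound 1 `CCC[C@H]1OC(=O)/C=C\C=C\[C@H](O)[C@@H](O)[C@@H]1[C@H](C)COC(=O)c1ccc(O)cc1` with 30000 nM
- compound 2 `CCC/C=C/[C@@H]1OC(=O)c2cc(O)cc(O)c2[C@@H]1O` with > 50000 nM as a limit
- compound 3 `CCC[C@@H]1C[C@H](O)[C@@H](OC)/C=C/C=C\C(=O)O1` with > 50000 nM as a limit

Compound 3 stands at the limit of > 50000 nM in this assay, at which 2 of the 3 values shown sit, and so has a limit rather than a number. Compound 4 `CCC[C@@H]1C[C@H](O)[C@@H](O)/C=C/C=C\C(=O)O1` differs from compound 3 in one place hydrogen in place of methyl on an oxygen on a saturated carbon with hydrogen in place of methyl on an oxygen on a saturated carbon, which is methoxy to hydroxy. Going by the values given here, no measured pair shows the effect of such a change, so no step beyond the usual scatter is expected in this assay in either direction. The estimated step of a number no higher from compound 3 to compound 4 (the limit leaves the size open) is therefore small. For compound 4 the expected value is 50000 nM with an estimated range from 20000 nM to 100000 nM and a limit may well take its place.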

Compound 4, half-maximal inhibitory concentration: 29000 nM
The estimate for compound 4 lay 1.7-fold (0.24 log units) above the measured number; the measured number falls inside the stated range.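

In this assay this oxygen now shows its first readable change: going from methoxy to hydroxy gives an at least 1.7-fold lower number from compound 3 to compound 4 (0.23 log units; that floor lies within the scatter). Compound 4 has a real number, so the hydroxy form falls within what the test can read. Compound 3 has only a limit, and the step therefore has a floor rather than a full size, because a limit is not a number: the limit of > 50000 nM in this assay, at which 2 of the 4 values shown sit.

The compounds shown leave open what an ethoxy group, an acetate ester or an amine would do in this place. Going by these compounds alone, they also leave open whether the same change behaves alike on another core, since only one pair carries it.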